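The source may hold more compounds than are shown below. What is called first, only, known or untested is meant among the compounds shown, and "the series" means these compounds.

Of the compounds shown here, three that share one core have been measured in a functional assay on HT-29 cells (Homo sapiens) for cytotoxicity, read by MTT assay, with a stated time of 72 h; a higher number here means a weaker inhibitor, a lower number a stronger inhibitor. Compound 3 `COc1cc2c(Oc3ccc(NC(=O)c4cn(-c5ccccc5Cl)nn4)cc3F)ccnc2cc1OCCCN1CCC(C)CC1` gives 130 nM, the lowest of the three numbers, though its gap to compound 2 lies within the scatter. Compound 2 `COc1cc2c(Oc3ccc(NC(=O)c4cn(-c5ccccc5)nn4)cc3F)ccnc2cc1OCCCN1CCC(C)CC1` gives 190 nM, and the step from compound 2 to compound 3, chloro in place of hydrogen on an aromatic carbon, amounts to a 1.5-fold lower number from compound 2 to compound 3 (0.16 log units; within the scatter). Among the measured compounds shown here, compound 1 `COc1cc2c(Oc3ccc(NC(=O)c4cn(-c5ccccc5F)nn4)cc3F)ccnc2cc1OCCCN1CCCCC1` gives 290 nM, a gap from compound 3 that is beyond the scatter, but compound 1 also differs from compound 3 elsewhere in the molecule, so no single step links the two. Compound 4 `COc1cc2c(Oc3ccc(NC(=O)c4cn(-c5ccccc5F)nn4)cc3F)ccnc2cc1OCCCN1CCC(C)CC1` has not yet been measured. It differs from compound 3 in one place: fluoro in place of chloro on an aromatic carbon. For the measured compounds named here, the only measured step that bears on this change is the one from compound 2 to compound 3, which stayed within the scatter; exchanging one halogen for another at the same place is expected to be a small step, a 1.4-fold higher number from compound 3 to compound 4 (0.14 log units; within the scatter), if anything toward a slightly higher number. Compound 4 is therefore estimated at 180 nM, with a range from 90 nM to 360 nM.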

Compound 4, half-maximal inhibitory concentration: 210 nM
Compound 4: the middle estimate sits 1.2-fold (0.07 log units) below what was measured; the measured number falls inside the stated range.
By their numbers in this assay, from the lowest: compounds 3, 2, 4 and 1 (each within the scatter of the next, the first and the last beyond it).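

With compound 4, the aromatic carbon ortho to a large group has now carried hydrogen, chloro and fluoro, and in this assay exchanging chloro for fluoro gives a 1.6-fold higher number from compound 3 to compound 4 (0.21 log units; within the scatter), while fluoro in place of hydrogen gives a 1.1-fold higher number from compound 2 to compound 4 (0.04 log units; within the scatter). Together with the earlier chloro step, this shows that none of the three groups is separated from another by more than the scatter at this position, and compound 4 also links to compound 1 through a single change elsewhere in the molecule, methyl in place of hydrogen on a saturated ring carbon, which gives a 1.4-fold lower number from compound 1 to compound 4 (0.14 log units; within the scatter). Nothing available offers an explanation for these small steps.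

Going by these compounds, whether a methoxy, nitrile or amino group at this same place would move the number beyond the scatter remains open. Also open, on these data alone, is whether the methyl step would read the same with chloro or hydrogen in place of fluoro.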